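The source may report more compounds than this note shows. Statements on the series, on what has been measured and on what is new or still open speak of the compounds shown alone.

Measured in a functional assay on M21 cells (Homo sapiens) for inhibition, read by sulforhodamine B assay, with a stated time of 48 h; on this read-out higher numbers stand for weaker inhibition and lower numbers for stronger inhibition:
- compound 1 `CCNC(=O)Nc1ccc(/C=C/c2cccc(Cl)c2)cc1`: > 20000 nM
- compound 2 `CCNC(=O)Nc1ccc(/C=C\c2cc(OC)c(OC)c(OC)c2)cc1`: 21000 nM
- compound 3 `Cc1cc(C)cc(/C=C\c2ccc(N3CCNC3=O)cc2)c1`: 10 nM

The entry for compound 1 is a limit of the assay and not a number. Of the two actual numbers, compound 2 has the higher, at 21000 nM. Compound 3 lies far lower at 10 nM, a gap well beyond the scatter.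

Compound 4 `COc1cc(/C=C\c2ccc(N3CCNC3=O)cc2)cc(OC)c1OC` has not yet been measured. It differs from compound 2 as follows: 2-oxoimidazolidin-1-yl in place of (ethylcarbamoyl)amino on an aromatic carbon. The change puts 2-oxoimidazolidin-1-yl in place of (ethylcarbamoyl)amino on an aromatic carbon, para to a large group.

Going by the values given here, no measured pair isolates this change, so its size has to be inferred. Compound 3 carries the same 2-oxoimidazolidin-1-yl group and gives 10 nM, so a large drop beyond the scatter is expected in this assay. Compound 3 differs from compound 4 elsewhere in the structure, which leaves the expected size uncertain. The estimated step is a 210-fold lower number from compound 2 to compound 4 (2.32 log units; beyond the scatter). The estimated value for compound 4 is 100 nM, with an expected range of 10 nM to 2000 nM.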

Compound 4, half-maximal inhibitory concentration: 2.4 nM
The estimate for compound 4 lay 42-fold (1.62 log units) above the measured number; measured number below the stated range.
By their numbers in this assay, from the lowest: compound 4; then compound 3; then compound 2.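

In this assay, going by these compounds alone, 2-oxoimidazolidin-1-yl in place of (ethylcarbamoyl)amino on an aromatic carbon, para to a large group, gives an 8800-fold lower number from compound 2 to compound 4 (3.94 log units; beyond the scatter), and this is the first pair to isolate the change. The two groups match in heavy atoms as counted, so the pair differs in the five-membered non-aromatic ring and in the hydrogen-bond donor count. The upper end of the step lies near the top of the readable range, where compound 1 stands as a limit of the assay and not a number: the limit of > 20000 nM in this assay, at which 1 of the 4 values shown sits.

As far as these compounds go, whether the ring itself or the donor count carries the step stays open; an N-methyl group on the ring nitrogen or a six-membered cyclic urea at this position would separate the two. From the compounds shown here alone, whether the step carries over to cells other than those in this assay also stays open.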